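The source may report more compounds than this note shows. Statements on the series, on what has been measured and on what is new or still open speak of the compounds shown alone.

Series notes. Compound 1 `O=C(CSc1nc2ccccc2[nH]1)c1ccc(Br)cc1` gives 43000 nM in a functional assay on HT-29 cells (Homo sapiens) for inhibition, read by WST assay, with a stated time of 48 h; on this read-out higher numbers stand for weaker inhibition and lower numbers for stronger inhibition. Compound 2 `O=C(CSc1nc2ccccc2[nH]1)c1ccc(O)cc1`, which carries hydroxy in place of bromo on the aromatic carbon, gives 19200 nM in this assay; the move a 2.2-fold lower number from compound 1 to compound 2 (0.35 log units; beyond the scatter) is a modest gain in inhibition. Within the data shown here, on the two numbers available compound 2 stands lowest, with compound 1 as its only neighbour.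

Compound 3 `CCOc1ccc(C(=O)CSc2nc3ccccc3[nH]2)cc1` is the next member. Against compound 2 the change is ethyl in place of hydrogen on an oxygen on an aromatic ring, so the phenol oxygen keeps its position and only the ethyl group is added. Among the measured compounds shown here, no measured pair varies what sits on this oxygen; the only step in hand, the bromo to hydroxy exchange from compound 1 to compound 2, concerns a different kind of change and was itself of modest size. The expectation for this assay is therefore a step of no more than that size from compound 2 to compound 3, in either direction, and most probably one that does not clear the scatter. Compound 3 is accordingly expected to give about 25000 nM in this assay, within 8000 nM to 75000 nM, which corresponds to an expected step of a 1.3-fold higher number from compound 2 to compound 3 (0.11 log units; within the scatter).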

Compound 3, half-maximal inhibitory concentration: > 100000 nM
Compound 3 was reported as a limit (the forecaster's own chance of this, stated with the estimate: 10%); at least 4.0-fold (0.60 log units) between middle value and limit.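

In this assay, compound 3 is reported only as a limit and not as a number: the limit of > 100000 nM in this assay, at which 1 of the 3 values shown sits.

Even so, the step can be read in one direction. Adding ethyl on the oxygen of compound 2 gives an at least 5.2-fold higher number from compound 2 to compound 3 (0.71 log units; beyond the scatter), so this oxygen on the aromatic ring is not a place where substitution leaves the read-out unchanged, and the earlier bromo to hydroxy exchange gave no sign of this. The ethoxy group also falls on the weaker side of bromo, with an at least 2.3-fold higher number from compound 1 to compound 3 (0.36 log units; beyond the scatter), so the three groups at this place read in the order hydroxy, bromo, ethoxy from stronger to weaker inhibition, and the change at this place moves the read-out in both directions.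

The compounds shown leave open how far the true value of the ethoxy compound lies past its limit, and whether the step follows the loss of the hydrogen on this oxygen or the ethyl chain that enters. A methoxy group, a longer chain ending in an amine, or an amine in place of the hydroxy on the aromatic carbon would help separate these readings.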